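The source may report more compounds than this note shows. Statements on the series, on what has been measured and on what is new or still open speak of the compounds shown alone.

Compound 1 `CCCC(=O)Nc1ncc(-c2ccc(OC)cc2)n1C` carries a propyl group on its amide carbonyl. In a toxicity assay on THP-1 cells (Homo sapiens) for inhibition (a higher number here means that more compound is tolerated, a lower number that less compound is tolerated), compound 1 gives > 100000 nM, which is a limit of the measurement and not a number. Compound 2 `Cn1c(-c2ccc(C#N)cc2)cnc1NC(=O)c1ccc(F)cc1` also stops at a limit in this assay, with > 50000 nM. Compound 3 `COc1ccc2nc(NC(=O)c3ccc(F)cc3)n(C)c2c1` likewise ends at a limit in this assay, giving > 100000 nM. The picture is uniform: the limit of > 100000 nM in this assay, at which 2 of the 3 values shown sit, and (the limit of > 50000 nM in this assay, at which 1 of the 3 values shown sits). Compound 4 `COc1ccc(-c2cnc(NC(=O)c3cccc(OC)c3)n2C)cc1` has not yet been measured. It differs from compound 1 by 3-methoxyphenyl in place of propyl on a carbonyl carbon. With only limits known so far, no shift beyond the scatter is expected, estimated as a number no higher from compound 1 to compound 4 (the limit leaves the size open). Compound 4 is therefore expected to give about 100000 nM, in a range from 50000 nM to 200000 nM, most likely again reported as a limit.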

Compound 4, half-maximal cytotoxic concentration: > 100000 nM
Compound 4 gave a limit, no number (the forecaster's own chance of this, stated with the estimate: 80%); the middle value lies on the limit itself.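

Compound 1 and compound 4 both end at a limit in this assay, so the step between them cannot be read. The compounds shown leave open at what concentration any of them would reach half-maximal cytotoxicity.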